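The source may report more compounds than this note shows. Statements on the series, on what has been measured and on what is new or still open speak of the compounds shown alone.

Compound 1 `COc1ccc2nc(C)cc(OCC(=O)Nc3cc(C)cc(C)c3)c2c1` gives 26000 nM in a physicochemical assay for solubility, in phosphate buffer, measured as kinetic solubility, with a stated time of 1 h, at pH 7.4 (a lower number here means a less soluble compound, a higher number a more soluble compound), the second highest of the three numbers seen. Compound 2 `Cc1cc(C)cc(NC(=O)COc2cc(C)nc3ccc(F)cc23)c1` gives 28000 nM in this assay, and the step of a 1.1-fold higher number from compound 1 to compound 2 (0.03 log units; within the scatter) lies within the scatter. Compound 3 `CCCc1cc(OCC(=O)Nc2cc(C)cc(C)c2)c2cc(OC)ccc2n1` gives 12000 nM in this assay, and the step of a 2.2-fold lower number from compound 1 to compound 3 (0.34 log units; beyond the scatter) is the only one beyond the scatter. Compound 4 `COc1ccc2nc(C)cc(OCC(=O)Nc3cc(C)ccc3C)c2c1` differs from compound 1 by 2,5-dimethylphenyl in place of 3,5-dimethylphenyl on an amide-type nitrogen. Neither measured step touches the amide-type nitrogen, and neither bears directly on this change: one rearranges nothing, the other adds an ethyl. With the same atoms joined differently, compound 4 is expected to show no step beyond the scatter, a 1.1-fold lower number from compound 1 to compound 4 (0.03 log units; within the scatter). Compound 4 is therefore estimated at 24000 nM, between 12000 nM and 48000 nM.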

Compound 4, solubility: 45500 nM
The estimate for compound 4 lay 1.9-fold (0.28 log units) below the measured number; the measured number falls inside the stated range.
By their numbers in this assay, from the lowest: compound 3; then compounds 1, 2 and 4 (each within the scatter of the next).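

In this assay, 2,5-dimethylphenyl in place of 3,5-dimethylphenyl on the amide-type nitrogen gives a 1.8-fold higher number from compound 1 to compound 4 (0.24 log units; within the scatter). This is the only step shown at this place, and this rearrangement of the same atoms stays within the scatter. Nothing shown gives a reason for this step.

On these data alone, whether other groups on this nitrogen would also stay within the scatter remains open, for example plain phenyl or a phenyl ring carrying an amine or a carboxylic acid. Also open, as far as these compounds go, is whether a longer chain in place of either methyl would do so.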